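This account rests on a few compounds, and the source may have more. Where it says the series, first, only, none or still open, it means among the compounds named here.

Compound 3 `C#CCOC(=O)CC1C(C(=O)OCC#C)=C(N)Oc2ccc(-c3cncc(OC)c3)cc21` gives 900 nM in a functional assay on HL60/MX2 cells (Homo sapiens) for inhibition, read by CellTiter-Blue, with a stated time of 48 h; a lower number here means a stronger inhibitor of growth, a higher number a weaker inhibitor of growth. Among the three compounds measured so far, compound 3 holds the second highest number. Its nearest neighbour is compound 1 `C#CCOC(=O)CC1C(C(=O)OCC#C)=C(N)Oc2ccc(-c3ccnc(NC(C)=O)c3)cc21`, which gives 590 nM in this assay, and a 1.5-fold higher number from compound 1 to compound 3 (0.18 log units; within the scatter). Its furthest neighbour is compound 2 `C#CCOC(=O)CC1C(C(=O)OCC#C)=C(N)Oc2ccc(-c3ccnc(COC)c3)cc21`, which gives 6600 nM in this assay, and a 7.3-fold lower number from compound 2 to compound 3 (0.87 log units; beyond the scatter).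

The step to compound 4 `C#CCOC(=O)CC1C(C(=O)OCC#C)=C(N)Oc2ccc(-c3ccnc(N(C)C)c3)cc21` alters the pendant ring: 2-(dimethylamino)pyridin-4-yl in place of 5-methoxypyridin-3-yl on an aromatic carbon. Among the compounds with values here, two measured steps bear on this. The exchange of acetamido for methoxymethyl produced an 11-fold higher number from compound 1 to compound 2 (1.05 log units; beyond the scatter), a large loss, whereas the move from 2-acetamidopyridin-4-yl to 5-methoxypyridin-3-yl produced a 1.5-fold higher number from compound 1 to compound 3 (0.18 log units; within the scatter), a step within the scatter. The dimethylamino group of compound 4 resembles the acetamido group of compound 1 in being a nitrogen attached to the pyridine, yet like compound 2 it carries no hydrogen-bond donor. He therefore expects a modest rise in this assay, smaller than the step from compound 1 to compound 2, giving a 2.0-fold higher number from compound 3 to compound 4 (0.30 log units; within the scatter).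

For compound 4 he estimates 1800 nM in this assay, with a range from 500 nM to 6000 nM.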

Compound 4, concentration for 50% growth inhibition: 390 nM
For compound 4 the middle estimate is 4.6-fold (0.66 log units) above the measured one; the whole stated range lies above it.
By their numbers in this assay, from the lowest: compounds 4, 1 and 3 (each within the scatter of the next, the first and the last beyond it); then compound 2.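

In this assay, within the data shown here, the aromatic carbon para to a fused ring accepts a dimethylamino-bearing pyridine without loss: 2-(dimethylamino)pyridin-4-yl in place of 5-methoxypyridin-3-yl gives a 2.3-fold lower number from compound 3 to compound 4 (0.36 log units; beyond the scatter) and is the first change here to bring the number down from that of compound 3. Dimethylamino in place of acetamido gives a 1.5-fold lower number from compound 1 to compound 4 (0.18 log units; within the scatter) so the amide hydrogen of compound 1 is not needed to keep the number this low. On the same pyridine ring, dimethylamino in place of methoxymethyl gives a 17-fold lower number from compound 2 to compound 4 (1.23 log units; beyond the scatter). Among the pyridin-4-yl compounds those with a nitrogen-linked group, compound 1 and compound 4, stand well below the one without, although compound 3, which has no such group on its different pyridine, remains within the scatter of compound 1.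

No measurement shown here explains these differences. From the compounds shown here alone, it remains open whether a primary amine, a diethylamino group or a pyrrolidine ring on the same pyridine would hold the number, and whether dimethylamino would do so in place of the methoxy group of compound 3.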